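The source may report more compounds than this note shows. Statements on the series, on what has been measured and on what is new or still open speak of the compounds shown alone.

Working notes on the series. Compound 1 `CCOc1ccccc1Nc1nc(SCc2ccc(C(F)(F)F)cc2)nc2ccccc12` gives 26200 nM in a functional assay on PC-3 cells (Homo sapiens) for cytotoxicity, read by MTT assay, with a stated time of 72 h (a higher number here means a weaker inhibitor, a lower number a stronger inhibitor), and compound 2 `O=[N+]([O-])c1ccc(Nc2nc(SCc3ccc(C(F)(F)F)cc3)nc3ccccc23)cc1` gives 7900 nM. Among the compounds with values here, of the two numbers known, compound 2 has the lower one; the step of a 3.3-fold lower number from compound 1 to compound 2 (0.52 log units; beyond the scatter) is the only measured move in the set.

Compound 3 `FC(F)(F)c1ccc(CSc2nc(Nc3ccc(C(F)(F)F)cc3)c3ccccc3n2)cc1` is not yet measured. It differs from compound 2 by trifluoromethyl in place of nitro on an aromatic carbon, para to a large group. Within the data shown here, no measured step touches this exchange: the one step known, from compound 1 to compound 2, swaps a whole phenyl substitution pattern and says nothing about nitro against trifluoromethyl at the same place. Without a bearing step, no move beyond the scatter is expected in either direction; the expected step of a 1.3-fold higher number from compound 2 to compound 3 (0.10 log units; within the scatter) is small. Compound 3 is therefore expected to give about 10000 nM, within 4000 nM to 25000 nM.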

Compound 3, half-maximal inhibitory concentration: 7880 nM
Estimate against measurement, compound 3: 1.3-fold (0.10 log units) above; measured number inside the range.
By their numbers in this assay, from the lowest: compounds 3 and 2 (each within the scatter of the next); then compound 1.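

Trifluoromethyl in place of nitro, on an aromatic carbon para to a large group, is the first exchange read at this place with the rest of the molecule held constant, and it gives a 1.0-fold lower number from compound 2 to compound 3 (0.00 log units; within the scatter) in this assay. Against the 2-ethoxyphenyl compound, 4-(trifluoromethyl)phenyl gives a 3.3-fold lower number from compound 1 to compound 3 (0.52 log units; beyond the scatter), the same printed size as a 3.3-fold lower number from compound 1 to compound 2 (0.52 log units; beyond the scatter), so among these compounds the lower number does not depend on nitro. No measurement is at hand that explains either step.

As far as these compounds go, with only these compounds, it stays open whether the lower numbers follow from losing 2-ethoxyphenyl or from having a group at the place para to a large group. An amine or a carboxylic acid at that place would test whether the match between nitro and trifluoromethyl extends to other groups.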